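A few compounds are considered here, and "the series" means these few. Any claim that something is new, unique, unknown or untested is made for them only; others in the source may bear on it.

Compound 1 `Cc1c(C)c2c(c(C)c1O)CCC(C)(/C=[N+](\[O-])C(C)(C)C)O2` gives 5500 nM
Compound 2 `COc1c(C)c(C)c2c(c1C)CCC(C)(/C=[N+](\[O-])C(C)(C)C)O2` gives 2940000 nM

In a functional assay for inhibition, with Rattus norvegicus as the target (on this read-out lower numbers stand for stronger inhibition and higher numbers for weaker inhibition), compound 1 stands at 5500 nM as the lower of the two numbers. Compound 3 `Cc1c(C)c2c(c(C)c1O)CCC(C)(/C=[N+](\[O-])C1CC1)O2` differs from compound 1 by cyclopropyl in place of tert-butyl on a double-bonded nitrogen with cyclopropyl in place of tert-butyl on a double-bonded nitrogen. For the measured compounds named here, the only measured step of a 530-fold higher number from compound 1 to compound 2 (2.73 log units; beyond the scatter) is large, but it concerns methyl in place of hydrogen on an oxygen on an aromatic ring, so it does not speak to this place. Only a modest rise is therefore expected, with a 1.3-fold higher number from compound 1 to compound 3 (0.10 log units; within the scatter) as the estimated step and its direction uncertain. Compound 3 is estimated at 7000 nM with an expected range from 1500 nM to 35000 nM in this read-out.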

Compound 3, half-maximal inhibitory concentration: 6000 nM
Compound 3: middle estimate off by 1.2-fold (0.07 log units), on the high side; measured number inside the range.
By their numbers in this assay, from the lowest: compounds 1 and 3 (each within the scatter of the next); then compound 2.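

In this assay, cyclopropyl in place of tert-butyl on a double-bonded nitrogen gives a 1.1-fold higher number from compound 1 to compound 3 (0.04 log units; within the scatter), so the read-out does not separate these two groups at this position. For the compounds shown here, the earlier compounds spoke only to the oxygen on the aromatic ring, and this is the first sign that the nitrogen substituent can change from an open branched group to a three-membered ring without a measurable shift. No measurement at hand accounts for this result. The compounds shown leave open whether an amine or a longer chain on that nitrogen would keep the number in this range, and whether methyl on the aromatic oxygen has as large an effect with cyclopropyl on the nitrogen.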